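Removing the acetyl group on a coumarin-furoxan hybrid

The source may hold more compounds than are shown below. What is called first, only, known or untested is meant among the compounds shown, and "the series" means these compounds.

Measured compounds in a functional assay on MCF7 cells (Homo sapiens) for inhibition, read by MTT assay, with a stated time of 48 h, tested at 10 uM; on this read-out higher numbers stand for more inhibition at the one concentration tested (going by the name of the read-out) and lower numbers for less inhibition:

compound 1, `COc1cc2cc(NC(C)=O)c(=O)oc2cc1OCCCOc1no[n+]([O-])c1S(=O)(=O)c1ccccc1`: 88.5%
compound 2, `COc1cc2cc(NC(C)=O)c(=O)oc2cc1OCCCCOc1no[n+]([O-])c1S(=O)(=O)c1ccccc1`: 80.4%
compound 3, `COc1cc2cc(N)c(=O)oc2cc1OCCCOc1no[n+]([O-])c1S(=O)(=O)c1ccccc1`: 91.6%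

Compound 1 and compound 2 differ in their cores; the difference between the two cores is not broken down here. Compound 3 differs from compound 1 by one change, (hydrogen in place of acetyl on a nitrogen on an aromatic ring), and that change made a step of a number 3.1 percentage points higher from compound 1 to compound 3 (within the scatter). The unmeasured compound 4, `COc1cc2cc(N)c(=O)oc2cc1OCCCCOc1no[n+]([O-])c1S(=O)(=O)c1ccccc1`, carries the same change on the core of compound 2: hydrogen in place of acetyl on a nitrogen on an aromatic ring. The place of the change is described in the same words for both pairs, so it counts as the same change. The step from compound 2 to compound 4 is expected to be a number 3.6 percentage points higher from compound 2 to compound 4 (within the scatter), because the earlier step of a number 3.1 percentage points higher from compound 1 to compound 3 (within the scatter) stayed within the scatter. Compound 4 is therefore estimated at 84%, with a likely range from 74% to 93%.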

Compound 4, a percentage reported as inhibition, at one concentration (the size of the read-out at that concentration, not a potency): 89%
For compound 4 the middle estimate is 5 percentage points below the measured one; low and high end bracket the measured number.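

In this assay, the acetamido to amino change gives a number 8.6 percentage points higher from compound 2 to compound 4 (within the scatter). On the two cores shown, the change behaves alike, since the two steps do not differ beyond what repeat measurements would give: the same change on two cores in this assay, a number 3.1 percentage points higher (within the scatter) from compound 1 to compound 3 and a number 8.6 percentage points higher (within the scatter) from compound 2 to compound 4, 5.5 percentage points apart, within the scatter of two such steps

Neither step lies beyond the scatter, so this agreement does not show that swapping acetyl for hydrogen alters inhibition on either core, and two cores cannot show how the change behaves on others. The compounds shown leave open what other groups on that nitrogen, such as a methyl or a benzoyl group, would give. They also leave open whether the same agreement would hold on a core with a longer chain.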